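This account rests on a few compounds, and the source may have more. Where it says the series, first, only, none or still open, it means among the compounds named here.

Working notes on the series. Compound 1 `CCN(c1ccccc1)S(=O)(=O)c1cc(Cl)ccc1Cl`, compound 2 `CCN(c1ccccc1Cl)S(=O)(=O)c1cc(Cl)ccc1Cl` and compound 3 `CCN(c1ccc(Cl)cc1C)S(=O)(=O)c1cc(Cl)ccc1Cl` are measured; compound 4 `CCN(c1c(C)cc(Cl)cc1Cl)S(=O)(=O)c1cc(Cl)ccc1Cl` is not yet measured. In an ADME assay on A549 cells (Homo sapiens) for cytotoxicity, read by MTT assay (a lower number here means that less compound is tolerated, a higher number that more compound is tolerated), compound 1 gives > 5000 nM, which is a limit of the assay and not a number. In this assay compound 2 gives > 5000 nM, again a limit. In this assay compound 3 gives > 5000 nM, also a limit. The change from compound 1 to compound 2 is chloro in place of hydrogen on an aromatic carbon, and the step it made is a step that the two limits leave unreadable from compound 1 to compound 2. How the core of compound 3 differs from the core of compound 1 is not broken down here. From compound 3 to compound 4 the same kind of change is made, (chloro in place of hydrogen on an aromatic carbon); around the place it differs in that the entering group is meta to a chloro group and meta to a methyl group. All three measured values sit at one point, (the limit of > 5000 nM in this assay, at which 3 of the 3 values shown sit). In this assay the expected step is a step that the limit leaves unreadable from compound 3 to compound 4, an expectation resting on a step that the two limits leave unreadable from compound 1 to compound 2 and on (the limit of > 5000 nM in this assay, at which 3 of the 3 values shown sit). Compound 4 is expected near 8000 nM, estimated between 3000 nM and 30000 nM.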

Compound 4, half-maximal cytotoxic concentration: > 5000 nM
Compound 4: a limit, no number; the forecaster's own chance of this, stated with the estimate: 75%; the middle value lies beyond the limit too.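

In this assay compound 4 gives > 5000 nM, which is a limit of the assay and not a number. The step from compound 3 to compound 4 therefore cannot be read. The compounds shown leave open what concentration of any of them is tolerated, and whether chloro in place of hydrogen changes it: the limit of > 5000 nM in this assay, at which 4 of the 4 values shown sit.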